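The compounds below may be only part of what the source reports. "The series", "measured", "known", "first", "only" and "open" are said of these compounds alone.

Within the data shown here, compound 2 `COc1ccc(-c2c(C#N)c(N)nc(SCc3csc(-c4ccccc4Cl)n3)c2C#N)cc1` gives 11 nM in an assay on CHO cells for displacement of a labelled ligand from adenosine receptor A1 (Homo sapiens) (on this read-out higher numbers stand for weaker inhibition and lower numbers for stronger inhibition), the lower of the two numbers measured so far; compound 1 `COc1ccc(-c2c(C#N)c(N)nc(SCc3csc(-c4ccc(Br)cn4)n3)c2C#N)cc1` gives 53 nM. Among the measured compounds shown here, the single measured step, a 4.8-fold lower number from compound 1 to compound 2 (0.68 log units; beyond the scatter), is modest and lies beyond the scatter. Compound 3 `COc1ccc(-c2c(C#N)c(N)nc(SCc3csc(-c4ccc(F)cc4)n3)c2C#N)cc1` carries 4-fluorophenyl in place of 2-chlorophenyl on an aromatic carbon. For the measured compounds named here, no measured step swaps one phenyl for another, so the step of a 4.8-fold lower number from compound 1 to compound 2 (0.68 log units; beyond the scatter) bears only loosely on this change; no direction is clearly favoured, and a step within or just beyond the scatter is expected. For compound 3 the expected value is 20 nM (range 6 nM to 70 nM), an expected step of a 1.8-fold higher number from compound 2 to compound 3 (0.26 log units; within the scatter).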

Compound 3, inhibition constant: 2.3 nM
Compound 3: the middle estimate sits 8.7-fold (0.94 log units) above what was measured; measured number outside the range, below it.
By their numbers in this assay, from the lowest: compound 3; then compound 2; then compound 1.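

At this aromatic carbon, exchanging one phenyl group for another still shifts the number in this assay: 4-fluorophenyl in place of 2-chlorophenyl gives a 4.8-fold lower number from compound 2 to compound 3 (0.68 log units; beyond the scatter) and so the position is not indifferent to the substituted phenyl it carries. Against 5-bromopyridin-2-yl, the same 4-fluorophenyl gives a 23-fold lower number from compound 1 to compound 3 (1.36 log units; beyond the scatter) across the series so far. No measurement shown here accounts for either step.

The two phenyl groups differ in both halogen and its place on the ring, and these two changes cannot be separated here. As far as these compounds go, an unsubstituted phenyl or a methoxy group on the phenyl remains open at this position.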